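The source may report more compounds than this note shows. Statements on the series, on what has been measured and on what is new or still open speak of the compounds shown alone.

Compound 1 `CCN(Cc1ccccn1)c1cccc(C(=O)N2CCc3ccc(OS(N)(=O)=O)cc3C2)c1` belongs to a set of three compounds sharing one core and differing only in the amine attached to the aromatic ring beside the amide. In an assay on HEK293 cells for inhibition of Steryl-sulfatase (Homo sapiens), tested at 0.1 uM (a lower number here means a weaker effect, a higher number a stronger effect of the compound at the concentration tested), compound 1 gives 6.5%, the second highest of the three numbers. Compound 2 `CN(C)CCN(CCN(C)C)c1ccc(C(=O)N2CCc3ccc(OS(N)(=O)=O)cc3C2)cc1` gives 3.8%, which lies within the scatter of compound 1, so the two cannot be told apart. Compound 3 `CCN(Cc1cccnc1)c1ccc(C(=O)N2CCc3ccc(OS(N)(=O)=O)cc3C2)cc1` gives 35.7%, clearly above both.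

Compound 4 `CN(CCN1CCCCC1)c1cccc(C(=O)N2CCc3ccc(OS(N)(=O)=O)cc3C2)c1` has not been measured. It differs from compound 1 in a single place: methyl(2-(piperidin-1-yl)ethyl)amino in place of ethyl((pyridin-2-yl)methyl)amino on an aromatic carbon.

Going by the values given here, only one measured step bears on this change: a number 31.9 percentage points higher from compound 2 to compound 3 (beyond the scatter), where an open-chain amine was replaced by an amine carrying an aromatic heterocycle. The change to compound 4 runs the other way, an aromatic heterocycle leaving and a saturated amine chain entering. Since compound 1 already sits low, with 6.5%, little room remains for a fall, so the expected step of a number 1.5 percentage points lower from compound 1 to compound 4 (within the scatter) is none beyond the scatter. Compound 4 is therefore expected to give about 5%, within 0% to 18%.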

Compound 4, a percentage reported as inhibition, at one concentration (the size of the read-out at that concentration, not a potency): 24.5%
Beside the measured number, compound 4's estimate is 19.5 percentage points below it, outside the stated range (above it).
By their numbers in this assay, from the lowest: compounds 2 and 1 (each within the scatter of the next); then compound 4; then compound 3.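

In this assay, the exchange at this position, on an aromatic carbon meta to a large group, gives a number 18 percentage points higher from compound 1 to compound 4 (beyond the scatter), so a pyridine ring is not needed here for a higher number. The step of a number 31.9 percentage points higher from compound 2 to compound 3 (beyond the scatter) alone could have suggested that an aromatic heterocycle was the favourable feature, but the new step shows that a saturated piperidine ring can also outperform a pyridine-bearing amine. The two groups have the same counts of heavy atoms, carbons, nitrogens, donors and acceptors, so those counts do not separate them, and no supporting measurement explains the rise.

On these data alone, it remains open whether a morpholine ring in place of the piperidine ring would hold the higher number. The same question applies to a longer chain leading to the piperidine ring.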